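The source may report more compounds than this note shows. Statements on the series, on what has been measured and on what is new or still open speak of the compounds shown alone.

Compound 1 `COc1ccc(/C=C/C(=O)OC[C@@H](OCc2ccccc2)[C@H]2OC(=O)C=C[C@H]2OCc2ccccc2)cc1` and compound 2 `O=C1C=C[C@@H](OCc2ccccc2)[C@@H]([C@@H](COC(=O)/C=C/c2ccc(F)cc2)OCc2ccccc2)O1` share one core and differ in a single place, (fluoro in place of methoxy on an aromatic carbon). In a functional assay on A549 cells (Homo sapiens) for antiproliferative activity, read by MTT assay, with a stated time of 6 days (a higher number here means a weaker inhibitor, a lower number a stronger inhibitor), compound 1 gives 4250 nM, while compound 2 gives 12100 nM; that change is measured as a 2.8-fold higher number from compound 1 to compound 2 (0.45 log units; beyond the scatter). Compound 3 `COc1ccc(/C=C/C(=O)OC[C@@H](OC(C)=O)[C@H]2OC(=O)C=C[C@H]2OC(C)=O)cc1` is built on a different core, and how that core differs from the core of compound 1 is not broken down here. In this assay compound 3 gives 1400 nM, the lowest of the three numbers, with its gaps to compound 1 and to compound 2 both lying beyond the scatter. Compound 4 `CC(=O)O[C@@H]1C=CC(=O)O[C@@H]1[C@@H](COC(=O)/C=C/c1ccc(F)cc1)OC(C)=O` has not yet been measured in this assay. It stands to compound 3 as compound 2 stands to compound 1: fluoro in place of methoxy on an aromatic carbon. The place is the same in both pairs, so this is the same change. Because a 2.8-fold higher number from compound 1 to compound 2 (0.45 log units; beyond the scatter) raised the number, the step from compound 3 to compound 4 is expected to be a 2.8-fold higher number from compound 3 to compound 4 (0.44 log units; beyond the scatter). That expectation rests on compound 3 at 1400 nM and on the earlier step. Compound 4 is therefore expected to give about 3900 nM in this assay, estimated to fall between 1500 nM and 10000 nM.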

Compound 4, half-maximal inhibitory concentration: 2120 nM
Estimate against measurement, compound 4: 1.8-fold (0.26 log units) above; the range from low to high includes it.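

In this assay, fluoro in place of methoxy on an aromatic carbon gives a 1.5-fold higher number from compound 3 to compound 4 (0.18 log units; within the scatter), which leaves compound 3 and compound 4 within the scatter of each other, whereas the same change on the core of compound 1 gave a 2.8-fold higher number from compound 1 to compound 2 (0.45 log units; beyond the scatter). The two steps cannot be told apart, so these two pairs give no sign that the core alters what this change does: the same change on two cores in this assay, a 2.8-fold higher number (0.45 log units; beyond the scatter) from compound 1 to compound 2 and a 1.5-fold higher number (0.18 log units; within the scatter) from compound 3 to compound 4, 1.9-fold (0.27 log units) apart, within the scatter of two such steps. This does not show that the step has the same size on both cores, as one lies beyond the scatter and the other within it, and two pairs cannot establish a rule for the series.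

From the compounds shown here alone, only methoxy and fluoro appear at this place, so it remains open how a chloro group, a nitrile or an amine would behave there. Going by these compounds, it also remains open whether the change would carry over to any core beyond these two.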